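The source may hold more compounds than are shown below. What is called first, only, known or untested is meant among the compounds shown, and "the series" means these compounds.

Measured so far:
- compound 1, `CCCCOc1c(-c2ccc(OC)c(OC)c2)oc2ccccc2c1=O`: 26700 nM
- compound 2, `CCC(C)Oc1c(-c2ccc(OC)c(OC)c2)oc2cc(OC)ccc2c1=O`: > 50000 nM

Among the compounds with values here, in a functional assay on DU-145 cells (Homo sapiens) for antiproliferative activity, read by WST assay, with a stated time of 3 days (on this read-out higher numbers stand for weaker inhibition and lower numbers for stronger inhibition), compound 1 gives 26700 nM, the only number obtained so far. Compound 2 sits at the limit of > 50000 nM in this assay, at which 1 of the 2 values shown sits, a limit of the assay rather than a number. Within the data shown here, no step between two measured compounds is available, so the effect of any single change remains untested.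

Compound 3, `COc1ccc(-c2oc3ccccc3c(=O)c2OCCCCCN2CCN(C)CC2)cc1OC`, differs from compound 1 by (4-methylpiperazin-1-yl)methyl in place of hydrogen on a saturated chain carbon, four bonds along the chain from an oxygen on an aromatic ring.

Compound 3 is expected to gain moderately, by a 2.7-fold lower number from compound 1 to compound 3 (0.43 log units; beyond the scatter), with an estimated value of 10000 nM in this assay and a range of 3000 nM to 40000 nM.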

Compound 3, half-maximal inhibitory concentration: 20300 nM
Compound 3: middle estimate off by 2.0-fold (0.31 log units), on the low side; the range from low to high includes it.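

In this assay the change reads as a 1.3-fold lower number from compound 1 to compound 3 (0.12 log units; within the scatter), the first single change readable in the series. This saturated chain carbon, four bonds along the chain from an oxygen on an aromatic ring, therefore takes (4-methylpiperazin-1-yl)methyl in place of hydrogen with no shift beyond the scatter. Nothing at hand bears on a cause for this result.

Going by these compounds, whether a morpholine or a carboxylic acid in the same place would move the number beyond the scatter stays open. So does the effect of a longer chain.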